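Benzyl thioether expected to restore lost inhibition

The source may hold more compounds than are shown below. What is called first, only, known or untested is meant among the compounds shown, and "the series" means these compounds.

Compound 1 `Cc1cc(Nc2cc(-c3ccccc3)[nH]n2)n2ncnc2n1` gives > 50000 nM in a functional assay on PC-9 cells (Homo sapiens) for inhibition, read by MTT assay, with a stated time of 72 h; on this read-out higher numbers stand for weaker inhibition and lower numbers for stronger inhibition. Compound 2 `Cc1cc(Nc2cc(-c3ccccc3)[nH]n2)n2nc(SCc3ccc(C(F)(F)F)cc3)nc2n1` gives 4240 nM. Compound 3 `CCCSc1nc2nc(C)cc(Nc3cc(-c4ccccc4)[nH]n3)n2n1` gives > 50000 nM.

The value of compound 3 is a limit of this assay, not a number. Compound 1 also sits at a limit. Both belong to the limit of > 50000 nM in this assay, at which 2 of the 3 values shown sit, so the step that the two limits leave unreadable from compound 1 to compound 3 cannot be read. Within the data shown here, the one readable step is an at least 11-fold higher number from compound 2 to compound 3 (1.07 log units; beyond the scatter), and it is the step that bears on compound 4 `COc1ccc(CSc2nc3nc(C)cc(Nc4cc(-c5ccccc5)[nH]n4)n3n2)cc1`: the change 4-methoxyphenyl in place of ethyl on a saturated chain carbon bound to a sulfur is largely the reverse of it, with 4-methoxyphenyl now standing where 4-(trifluoromethyl)phenyl stood in compound 2. A lower number than the limit of compound 3 is therefore expected for compound 4 because an at least 11-fold higher number from compound 2 to compound 3 (1.07 log units; beyond the scatter) was large and beyond the scatter, although the exchange of trifluoromethyl for methoxy on the phenyl leaves the size uncertain. The estimate for compound 4 is 6000 nM, within 1500 nM to 30000 nM. This estimate means an expected step of an at least 8.3-fold lower number from compound 3 to compound 4 (0.92 log units; beyond the scatter).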

Compound 4, half-maximal inhibitory concentration: 8110 nM
For compound 4 the middle estimate is 1.4-fold (0.13 log units) below the measured one, within the range that was stated.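

In this assay, activity at this position is not tied to the trifluoromethyl group: exchanging it for methoxy on an aromatic carbon gives a 1.9-fold higher number from compound 2 to compound 4 (0.28 log units; within the scatter), so the two benzyl thioethers cannot be told apart. The 4-methoxybenzyl group also clearly separates from the propyl group, with an at least 6.1-fold lower number from compound 3 to compound 4 (0.78 log units; beyond the scatter), and from the hydrogen of the unsubstituted core, with an at least 6.1-fold lower number from compound 1 to compound 4 (0.78 log units; beyond the scatter), and both sizes are minimum values only. Compound 1 and compound 3 each stand at a limit, not a number: the limit of > 50000 nM in this assay, at which 2 of the 4 values shown sit.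

From the compounds shown here alone, it remains open whether the gain requires the phenyl ring itself or would also come with a longer chain such as octyl on the sulfur. How an amine or a carboxylic acid on the phenyl ring would read out is also unknown, as only methoxy and trifluoromethyl are shown there.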